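Fluoro Removal Repeated: Expected Growth Inhibition of Compound 4

A few compounds are considered here, and "the series" means these few. Any claim that something is new, unique, unknown or untested is made for them only; others in the source may bear on it.

Compound 1 `COc1cc(OC)cc(-c2ccc(-c3ccc(C(=N)N)c(F)c3)s2)c1` was tested in a functional assay on MCF7 cells (Homo sapiens) for inhibition, read by sulforhodamine B assay, with a stated time of 48 h (a higher number here means a weaker inhibitor of growth, a lower number a stronger inhibitor of growth), where compound 1 gives 194 nM. Compound 2 `N=C(N)c1ccc(-c2ccc(-c3ccc(Cl)cc3)s2)cc1F` gives 168 nM in this assay, and compound 3 `N=C(N)c1ccc(-c2ccc(-c3ccc(Cl)cc3)s2)cc1` gives 171 nM. The difference between the cores of compound 1 and compound 2 is not broken down here. From compound 2 to compound 3 the change is hydrogen in place of fluoro on an aromatic carbon, and it made a 1.0-fold higher number from compound 2 to compound 3 (0.01 log units; within the scatter). The same change, (hydrogen in place of fluoro on an aromatic carbon), turns compound 1 into compound 4 `COc1cc(OC)cc(-c2ccc(-c3ccc(C(=N)N)cc3)s2)c1`, which has not yet been measured. Because the earlier step was a 1.0-fold higher number from compound 2 to compound 3 (0.01 log units; within the scatter), the expected step is a 1.0-fold higher number from compound 1 to compound 4 (0.00 log units; within the scatter). In this assay compound 4 is therefore estimated at 195 nM, with the expected range running from 100 nM to 390 nM.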

Compound 4, concentration for 50% growth inhibition: 1220 nM
Estimate against measurement, compound 4: 6.3-fold (0.80 log units) below; measured number outside the range, above it.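

In this assay, hydrogen in place of fluoro on an aromatic carbon gave a 6.3-fold higher number from compound 1 to compound 4 (0.80 log units; beyond the scatter). The change therefore did not carry over from one core to the other with the same size, and the two steps stand clearly apart: the same change on two cores in this assay, a 1.0-fold higher number (0.01 log units; within the scatter) from compound 2 to compound 3 and a 6.3-fold higher number (0.80 log units; beyond the scatter) from compound 1 to compound 4, 6.2-fold (0.79 log units) apart, beyond the scatter of two such steps. This shows that the effect of removing fluoro depends on the core in these two pairs, but it does not show which difference between the cores is responsible, nor does it give a rule for any other core.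

The compounds shown leave open how a hydroxyl or a methyl group in place of the fluoro would behave on either core. They also leave open whether a single methoxy group would give a step like that of compound 1 or that of compound 2.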